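The source may report more compounds than this note shows. Statements on the series, on what has been measured and on what is new or still open speak of the compounds shown alone.

Measured so far in a functional assay on THP-1 cells (Homo sapiens) for inhibition, read by sulforhodamine B assay, with a stated time of 48 h; on this read-out higher numbers stand for weaker inhibition and lower numbers for stronger inhibition:
Compound 1 `COc1ccc(C(c2ccccc2O)c2cccc3ccccc23)c(OC)c1OC`: > 20000 nM
Compound 2 `COc1ccc(C(c2ccc(O)cc2)c2cccc3ccccc23)c(OC)c1OC`: 9450 nM

Among the measured compounds shown here, compound 2 holds the only true number in this small set, 9450 nM. For compound 1 the entry > 20000 nM is a limit and not a number.

The next compound is compound 3 `COc1ccc(C(OCc2ccc(C)cc2)c2cccc3ccccc23)c(OC)c1OC`, whose structural change is (4-methylbenzyl)oxy in place of 4-hydroxyphenyl on a saturated chain carbon bound to two aromatic carbons. The hydroxyphenyl group of compound 2 is therefore replaced outright, and the new group has no hydrogen-bond donor.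

For the measured compounds named here, only one measured step bears on this change, and it bears only indirectly: an at least 2.1-fold lower number from compound 1 to compound 2 (0.32 log units; beyond the scatter). It involves the same saturated chain carbon, but it exchanges one hydroxyphenyl group for another, so it gives no direct measure for a benzyl ether. It does show that a change at this place can shift the result in this assay by a modest amount. A modest step towards a higher number, meaning weaker inhibition, is therefore expected, and a limit may be reported instead of a number.

This estimate means an expected 1.5-fold higher number from compound 2 to compound 3 (0.17 log units; within the scatter). For compound 3 the estimated value is 14000 nM, with an expected range from 5000 nM to 30000 nM.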

Compound 3, half-maximal inhibitory concentration: > 20000 nM
Compound 3 gave a limit, no number; the forecaster's own chance of this, stated with the estimate: 35%; middle value at least 1.4-fold (0.15 log units) away from the limit.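

In this assay, among the compounds shown here, (4-methylbenzyl)oxy in place of 4-hydroxyphenyl on the saturated chain carbon gives an at least 2.1-fold higher number from compound 2 to compound 3 (0.32 log units; beyond the scatter), the first evidence here on a group at this place that is not a hydroxyphenyl. Compound 3 gives > 20000 nM, which is a limit and not a number. Compound 2 therefore remains the only compound shown with a true number, and the step between compound 1 and compound 3 cannot be read, since both entries are limits: the limit of > 20000 nM in this assay, at which 2 of the 3 values shown sit.

The compounds shown leave open whether the higher number of compound 3 goes with the missing hydrogen-bond donor or with the larger group of more heavy atoms, as this single step changes both at once. They also leave open whether an amine, a carboxylic acid or a (4-hydroxybenzyl)oxy group on this carbon would give a number in this assay, and how far any such group would stand from compound 2.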